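Compound 4: cyclohexyl on the amide-type nitrogen

This account rests on a few compounds, and the source may have more. Where it says the series, first, only, none or still open, it means among the compounds named here.

Measured in a functional assay on A-375 cells (Homo sapiens) for antiproliferative activity, read by MTT assay, with a stated time of 72 h; a higher number here means a weaker inhibitor, a lower number a stronger inhibitor:
- compound 1 `COc1cccc(N2C(=O)COc3ccc(-c4cnc(Cl)c(NS(=O)(=O)c5ccc(F)cc5)c4)cc32)c1`: > 40000 nM, a limit
- compound 2 `O=C1COc2ccc(-c3cnc(Cl)c(NS(=O)(=O)c4ccc(F)cc4)c3)cc2N1C1CCCCC1`: > 40000 nM, a limit
- compound 3 `COc1ncc(-c2ccc3c(c2)NC(=O)CO3)cc1NS(=O)(=O)c1ccc(F)cc1`: 26300 nM

Only compound 3 has a true number in this assay, 26300 nM. The other two results give no number, and the evidence here is the limit of > 40000 nM in this assay, at which 2 of the 3 values shown sit.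

Compound 4 `COc1ncc(-c2ccc3c(c2)N(C2CCCCC2)C(=O)CO3)cc1NS(=O)(=O)c1ccc(F)cc1` is made from compound 3 by one change: cyclohexyl in place of hydrogen on an amide-type nitrogen in a ring. In words, cyclohexyl takes the place of hydrogen on an amide-type nitrogen in a ring.

Among the measured compounds shown here, the only measured step at that nitrogen is a step that the two limits leave unreadable from compound 1 to compound 2, and it offers no size to carry over. For the measured compounds named here, no measured step goes from hydrogen to cyclohexyl there. Compound 2 carries cyclohexyl on that nitrogen and gives > 40000 nM, which is a limit. That result offers no sign of a gain in potency, though it does not set a size either.

The expectation is therefore no change beyond the scatter, with a real chance that compound 4 also reaches the limit. The estimated step is a 1.1-fold higher number from compound 3 to compound 4 (0.06 log units; within the scatter). For compound 4 the estimated value is 30000 nM, with an expected range of 12000 nM to 40000 nM.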

Compound 4, half-maximal inhibitory concentration: > 40000 nM
Compound 4: only a limit was reported; the forecaster's own chance of this, stated with the estimate: 40%; middle value at least 1.3-fold (0.12 log units) away from the limit.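

In this assay, among the compounds shown here, cyclohexyl in place of hydrogen on the amide-type nitrogen gives an at least 1.5-fold higher number from compound 3 to compound 4 (0.18 log units; that floor lies within the scatter), the first step at this position with any readable size, although only a floor can be given and that floor does not pass the scatter. The step therefore does not establish a real loss, but it does extend what compound 2 suggested: with methoxy on the aromatic carbon as well as with chloro, cyclohexyl at this nitrogen shows no sign of a gain in potency over the amide hydrogen. The steps that link compound 2 to the other compounds cannot be read, and the set now rests largely on a single limit: the limit of > 40000 nM in this assay, at which 3 of the 4 values shown sit.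

For the compounds shown here, compound 3 remains the only compound with a true number, so how far cyclohexyl actually moves the value is still unknown. Also open, on these data alone, is whether a smaller group such as methyl, or a short chain ending in an amine or a carboxylic acid, on this nitrogen would give a number that can be read against compound 3.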